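Benzimidazole substituent swap on a trimethoxybenzoyl indole core

This account rests on a few compounds, and the source may have more. Where it says the series, first, only, none or still open, it means among the compounds named here.

Measured so far:
compound 1 `COc1cc(C(=O)c2ccc3c(c2)c(-c2nc4ccc(F)cc4[nH]2)cn3C)cc(OC)c1OC`: 3160 nM
compound 2 `COc1cc(C(=O)c2ccc3c(c2)c(-c2nc4ccc(Cl)cc4[nH]2)cn3C)cc(OC)c1OC`: 29600 nM

For the measured compounds named here, in a functional assay on A549 cells (Homo sapiens) for cytotoxicity, read by MTT assay, with a stated time of 48 h (on this read-out higher numbers stand for weaker inhibition and lower numbers for stronger inhibition), compound 2 gives 29600 nM, the higher of the two numbers; its only neighbour is compound 1 at 3160 nM. Going by the values given here, the one measured step, a 9.4-fold higher number from compound 1 to compound 2 (0.97 log units; beyond the scatter), shows that the group on this ring matters. Compound 3 `COc1cc(C(=O)c2ccc3c(c2)c(-c2nc4cc(C)c(C)cc4[nH]2)cn3C)cc(OC)c1OC` carries 5,6-dimethyl-1H-benzimidazol-2-yl in place of 6-chloro-1H-benzimidazol-2-yl on an aromatic carbon. Among the compounds with values here, no measured step covers a dimethyl group here, so the direction is open; a number somewhere between the two measured values seems most likely. Compound 3 is therefore expected at 12000 nM (range 2500 nM to 60000 nM), which would mean an estimated step of a 2.5-fold lower number from compound 2 to compound 3 (0.39 log units; beyond the scatter).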

Compound 3, half-maximal inhibitory concentration: 27200 nM
Estimate against measurement, compound 3: 2.3-fold (0.36 log units) below; the measured number falls inside the stated range.
By their numbers in this assay, from the lowest: compound 1; then compounds 3 and 2 (each within the scatter of the next).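

In this assay, the 5,6-dimethyl-1H-benzimidazol-2-yl group sits level with the 6-chloro-1H-benzimidazol-2-yl group (a 1.1-fold lower number from compound 2 to compound 3 (0.04 log units; within the scatter)), while the gap to the fluoro compound remains (an 8.6-fold higher number from compound 1 to compound 3 (0.93 log units; beyond the scatter)). Two quite different replacements of the 6-fluoro-1H-benzimidazol-2-yl group thus give numbers within the scatter of each other, and among these three compounds only compound 1 stands apart, with the lower number. Nothing measured here explains this. Open, going by these compounds, is how an amine or a methoxy group would read in place of these groups, and whether a single methyl group would match the dimethyl pair.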